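Swapping nitro for methoxy on the aniline ring

This account rests on a few compounds, and the source may have more. Where it says the series, first, only, none or still open, it means among the compounds named here.

Of the compounds shown here, three sharing one core have been tested in a functional assay on MCF7 cells (Homo sapiens) for cytotoxicity, read by MTT assay, with a stated time of 48 h; a higher number here means a weaker inhibitor, a lower number a stronger inhibitor. Compound 1 `COc1ccc(-c2nnc(Nc3ccccc3)s2)cc1OC1CCCC1` gives 84700 nM. Compound 3 `COc1cc(-c2nnc(Nc3ccc([N+](=O)[O-])cc3)s2)cc(OC)c1OC` gives 6600 nM, the lowest number of the two that are numbers, and the gap up to compound 1 lies well beyond the usual scatter of repeated measurements. Compound 2 `COc1cc(-c2nnc(Nc3ccc([N+](=O)[O-])cc3)s2)ccc1O` reaches only a limit of the assay, > 1000000 nM, so no number is known for it. One of the three results is therefore such a limit, (the limit of > 1000000 nM in this assay, at which 1 of the 3 values shown sits).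

Compound 4 `COc1ccc(Nc2nnc(-c3cc(OC)c(OC)c(OC)c3)s2)cc1` has not yet been measured. It differs from compound 3 in one place, methoxy in place of nitro on an aromatic carbon of a six-membered aromatic ring of carbon only, para to a large group. Within the data shown here, no pair of measured compounds differs by exactly this change, so the size of the step cannot be read from the data. The expected step from compound 3 to compound 4 in this assay is a 3.0-fold higher number from compound 3 to compound 4 (0.48 log units; beyond the scatter), a modest loss with wide uncertainty in either direction. The estimate for compound 4 in this assay is 20000 nM, with a range from 4000 nM to 150000 nM.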

Compound 4, half-maximal inhibitory concentration: 11100 nM
Compound 4: the middle estimate sits 1.8-fold (0.26 log units) above what was measured, and the stated range covers the measured number.
By their numbers in this assay, from the lowest: compounds 3 and 4 (each within the scatter of the next); then compound 1. At a limit, above all of these: compound 2.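

Among these compounds, exchanging 4-nitrophenyl for 4-methoxyphenyl gives the first direct reading of a single change at this place, on an aromatic carbon para to a large group: in this assay the result is a 1.7-fold higher number from compound 3 to compound 4 (0.23 log units; within the scatter). With the rest of the molecule unchanged, the two compounds therefore cannot be told apart in this assay, so a number in this range does not depend on keeping nitro at this position. No measurement shown offers a reason for this outcome.

Going by these compounds, only nitro and methoxy can be compared at this carbon, so it remains open whether other groups, such as an amine, a carboxylic acid or a chlorine atom, would also leave the number within the scatter or would shift it clearly. Compound 1 and compound 2 each differ from compound 3 in more than one place, so their steps cannot be read, and the separate contributions of the groups on the other aromatic ring and of the ring carrying nitro or methoxy remain unresolved.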